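Swapping a benzoyloxy group for acetoxy: what to expect

This account rests on a few compounds, and the source may have more. Where it says the series, first, only, none or still open, it means among the compounds named here.

Of the compounds shown here, three sharing one core have been tested in a functional assay on HeLa cells (Homo sapiens) for inhibition, read by MTT assay, with a stated time of 72 h, tested at 10 ug/mL; a lower number here means less inhibition of growth, a higher number more inhibition of growth at the concentration tested. Compound 1 `C=C1[C@H](OC(C)=O)C[C@@H](OC(C)=O)C(C)(C)/C=C/[C@@H](C)C(=O)[C@@]2(OC(C)=O)C[C@@](C)(OC(C)=O)[C@H](OC(C)=O)[C@@H]2[C@H]1OC(C)=O` gives 11.4%. Compound 2 `C=C1[C@H](OCC(C)C)CC(=O)C(C)(C)/C=C/[C@@H](C)C(=O)[C@@]2(OC(C)=O)C[C@H](C)[C@H](OC(C)=O)[C@@H]2[C@H]1OC(C)=O` gives 19.1%. Compound 3 `C=C1[C@H](OC(C)=O)CC(=O)C(C)(C)/C=C/[C@@H](C)C(=O)[C@@]2(OC(C)=O)C[C@@](C)(OC(=O)c3ccccc3)[C@H](OC(C)=O)[C@@H]2[C@H]1OC(C)=O` gives 15.4%. Among these three numbers compound 3 stands second highest, but the spread is small: the nearest neighbour is compound 2, whose number is higher by an amount within the scatter, and the furthest is compound 1, whose number is lower by an amount that is also within the scatter. In short, nothing in this set separates one compound from another beyond the usual noise of this read-out.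

Compound 4 `C=C1[C@H](OC(C)=O)CC(=O)C(C)(C)/C=C/[C@@H](C)C(=O)[C@@]2(OC(C)=O)C[C@@](C)(OC(C)=O)[C@H](OC(C)=O)[C@@H]2[C@H]1OC(C)=O` has not yet been measured. It differs from compound 3 in one place methyl in place of phenyl on a carbonyl carbon: cut one bond further out, benzoyl gives way to acetyl, benzoyloxy to acetoxy. Going by the values given here, no measured pair in this set shows such a change, so nothing here tells how large its effect should be. Given that every measured number sits within the scatter of every other, the step from compound 3 to compound 4 is expected to be small, a number 1.4 percentage points lower from compound 3 to compound 4 (within the scatter), with no direction that could be read as beyond the scatter. Compound 4 is therefore estimated at 14%, somewhere between 4% and 26%.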

Compound 4, percent growth inhibition at one concentration: 17.3%
For compound 4 the middle estimate is 3.3 percentage points below the measured one; the measured number falls inside the stated range.
By their numbers in this assay, from the lowest: compounds 1, 3, 4 and 2 (each within the scatter of the next).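

In this assay, replacing phenyl with methyl on a carbonyl carbon, which turns benzoyloxy into acetoxy, gives a number 1.9 percentage points higher from compound 3 to compound 4 (within the scatter). Going by these compounds alone, this is the first pair in the set that differs in one place, and it shows that at this position the six-membered aromatic ring of the benzoyl group can give way to the single carbon of methyl without a step beyond the scatter at the one concentration tested. No measured property of these compounds bears on this result.

The compounds shown leave open whether another group on this carbonyl carbon, such as a longer chain like butyl, a carboxylic acid or an amine carried on the acyl group, would give a step beyond the scatter. They also leave open whether the exchange of benzoyloxy for acetoxy would read the same at other concentrations or on other cell lines, as this single pair speaks only for HeLa cells under the conditions of this one read-out.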